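The compounds below may be only part of what the source reports. "The series", "measured", "known", "first", "only" and "open" are said of these compounds alone.

Compound 1 `C=C(Br)C(=O)Nc1ccc(C(=O)/C=C/c2cccc(OC)c2OC)cc1`, compound 2 `C=C(Br)C(=O)Nc1ccc(C(=O)/C=C/c2ccc(OC)c(OC)c2)cc1` and compound 3 `C=C(Br)C(=O)Nc1ccc(C(=O)/C=C/c2ccc(OC)cc2OC)cc1` share one core and differ only in where their methoxy groups sit. In a functional assay on L1210 cells (Mus musculus) for antiproliferative activity, with a stated time of 48 h (on this read-out higher numbers stand for weaker inhibition and lower numbers for stronger inhibition), compound 1 gives 1100 nM and compound 2 gives 1300 nM, two values within the scatter of each other. Compound 3 gives 520 nM, the lowest of the three numbers, and its gaps to both others lie beyond the scatter.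

The untested compound 4 `C=C(Br)C(=O)Nc1ccc(C(=O)/C=C/c2ccc(OC)c(OC)c2OC)cc1` comes from compound 3 through one change: methoxy in place of hydrogen on an aromatic carbon, with methoxy in place of hydrogen on an aromatic carbon, ortho to two methoxy groups and meta to a large group. For the measured compounds named here, no measured pair shows the effect of such an addition, so only the spread of the three values in this assay can guide the expectation. The expected step, a 1.6-fold higher number from compound 3 to compound 4 (0.21 log units; within the scatter), is small and toward weaker inhibition, probably not beyond the scatter. For compound 4 the estimated value is 850 nM, with an expected range from 350 nM to 2000 nM.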

Compound 4, half-maximal inhibitory concentration: 630 nM
For compound 4 the middle estimate is 1.3-fold (0.13 log units) above the measured one; low and high end bracket the measured number.
By their numbers in this assay, from the lowest: compounds 3, 4, 1 and 2 (each within the scatter of the next, the first and the last beyond it).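

Methoxy in place of hydrogen at this position, ortho to two methoxy groups and meta to a large group, can now be read directly: in this assay the step is a 1.2-fold higher number from compound 3 to compound 4 (0.08 log units; within the scatter) and the two compounds cannot be told apart on this read-out. For the compounds shown here, the same trimethoxy compound, reached from the two other dimethoxy compounds, shows a 2.1-fold lower number from compound 2 to compound 4 (0.31 log units; beyond the scatter) and a 1.7-fold lower number from compound 1 to compound 4 (0.24 log units; within the scatter) so a third methoxy group does not weaken inhibition relative to any of the three, and only the step from compound 2 clears the scatter. Nothing shown here accounts for these steps.

Whether this position accepts anything other than methoxy stays open, since a hydroxyl group, an amine or a longer chain such as ethoxy does not appear among these compounds. As far as these compounds go, whether the pattern holds beyond L1210 cells also stays open.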